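This account rests on a few compounds, and the source may have more. Where it says the series, first, only, none or still open, it means among the compounds named here.

Within the data shown here, compound 1 `COc1ccc(N/C(CCNC2=CC(=O)c3ccccc3C2=O)=N\S(=O)(=O)c2ccc(C)cc2)cc1OC` is one of two compounds measured in a functional assay on HeLa cells (Homo sapiens) for cytotoxicity, read by MTT assay, with a stated time of 48 h; on this read-out higher numbers stand for weaker inhibition and lower numbers for stronger inhibition; in this assay compound 1 gives 14500 nM, the lower of the two numbers. Among the measured compounds shown here, its companion, compound 2 `Cc1ccc(S(=O)(=O)/N=C(/CCNC2=CC(=O)c3ccccc3C2=O)NC(C)C)cc1`, gives in this assay 30200 nM, and the only measured step, a 2.1-fold higher number from compound 1 to compound 2 (0.32 log units; beyond the scatter), is a modest one and concerns an isopropyl in place of 3,4-dimethoxyphenyl on an amine nitrogen. Compound 3 `COc1ccc(N/C(CCNC2=CC(=O)C(C)=C(C)C2=O)=N\S(=O)(=O)c2ccc(C)cc2)cc1OC` has not yet been measured. It differs from compound 1 at another position: a group of 10 heavy atoms (8 carbon, 2 oxygen; one six-membered non-aromatic ring of carbon only) in place of a group of 12 heavy atoms (10 carbon, 2 oxygen; one six-membered non-aromatic ring of carbon only, one six-membered aromatic ring of carbon only), on an amine nitrogen. For the measured compounds named here, no measured step touches this part of the shared core, so the step from compound 1 to compound 2 offers no direct guide; the change is a sizeable one in the quinone portion, and a step in this assay of uncertain direction is therefore expected, leaning toward a higher number. For compound 3 the estimate in this assay is 25000 nM, within a range of 8000 nM to 80000 nM, which corresponds to an expected step of a 1.7-fold higher number from compound 1 to compound 3 (0.24 log units; within the scatter).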

Compound 3, half-maximal inhibitory concentration: 10500 nM
The estimate for compound 3 lay 2.4-fold (0.38 log units) above the measured number, within the range that was stated.
By their numbers in this assay, from the lowest: compounds 3 and 1 (each within the scatter of the next); then compound 2.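

In this assay, putting the group of 10 heavy atoms in place of the group of 12 heavy atoms on an amine nitrogen gives a 1.4-fold lower number from compound 1 to compound 3 (0.14 log units; within the scatter) and so stays inside the usual scatter. Among these compounds, this is the first reading on this part of the shared core, and it shows that the six-membered aromatic ring of carbon only, present in the group that leaves and absent from the group that enters, can go without a change that can be told from the scatter in this assay.

From the compounds shown here alone, whether isopropyl in place of 3,4-dimethoxyphenyl would give the same step on a compound carrying the group of 10 heavy atoms remains open. So does the reading of a group bearing a chlorine atom or a morpholine at this place. Nothing on hand explains why the two numbers lie so close.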